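The source may hold more compounds than are shown below. What is called first, only, known or untested is meant among the compounds shown, and "the series" means these compounds.

Series notes. Compound 1 `NC(=O)c1c(NC(=O)c2ccccc2Cl)sc2c1CCN(Cc1ccccc1)C2` gives 14500 nM in a functional assay on MKN-74 cells (Homo sapiens) for antiproliferative activity, with a stated time of 24 h; a higher number here means a weaker inhibitor, a lower number a stronger inhibitor. Compound 2 `NC(=O)c1c(NC(=O)c2ccccc2Cl)sc2c1CCN(C(=S)Nc1ccccc1)C2` gives 15600 nM in this assay; the pair shows a 1.1-fold higher number from compound 1 to compound 2 (0.03 log units; within the scatter). Compound 3 `NC(=O)c1c(NC(=O)c2ccccc2Cl)sc2c1CCN(C(=S)Nc1ccccc1I)C2` gives 2630 nM in this assay, the lowest of the three numbers, set apart from compound 1 by a 5.5-fold lower number from compound 1 to compound 3 (0.74 log units; beyond the scatter) and from compound 2 by a 5.9-fold lower number from compound 2 to compound 3 (0.77 log units; beyond the scatter).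

Compound 4 `NC(=O)c1c(NC(=O)c2ccccc2Cl)sc2c1CCN(C(=O)Nc1c(Cl)cccc1Cl)C2` has not yet been measured. Against compound 3 the change is a group of 11 heavy atoms (7 carbon, 1 nitrogen, 1 oxygen, 2 chlorine; one six-membered aromatic ring of carbon only) in place of a group of 10 heavy atoms (7 carbon, 1 nitrogen, 1 sulfur, 1 iodine; one six-membered aromatic ring of carbon only), on an amine nitrogen in a ring: the thiocarbonyl of the thiourea gives way to the carbonyl of a urea, and the single iodo substituent gives way to the two chloro substituents of the (2,6-dichlorophenyl)carbamoyl group. Among the measured compounds shown here, no measured step isolates either part of this change. The step that bears most directly is a 5.9-fold lower number from compound 2 to compound 3 (0.77 log units; beyond the scatter), where a halogen on that aromatic ring moved the number beyond the scatter; a 1.1-fold higher number from compound 1 to compound 2 (0.03 log units; within the scatter) shows the unsubstituted phenylthiourea indistinguishable from the benzyl group of compound 1. Whether two chloro substituents on a urea keep what one iodo substituent on a thiourea gave is open, so a partial retention is the working assumption. Compound 4 is expected at 5000 nM, with a range of 1500 nM to 15000 nM. The expected step is a 1.9-fold higher number from compound 3 to compound 4 (0.28 log units; within the scatter), a modest rise that stays near the edge of the scatter.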

Compound 4, half-maximal inhibitory concentration: 24400 nM
For compound 4 the middle estimate is 4.9-fold (0.69 log units) below the measured one; measured number above the stated range.
By their numbers in this assay, from the lowest: compound 3; then compounds 1, 2 and 4 (each within the scatter of the next).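

In this assay, the gain seen with the iodo-bearing thiourea of compound 3 does not carry over to the (2,6-dichlorophenyl)carbamoyl group on the amine nitrogen in a ring (a 9.3-fold higher number from compound 3 to compound 4 (0.97 log units; beyond the scatter)), so a halogen on the aromatic ring of this group is not enough by itself to give a lower number. Compound 4 instead falls in with the two compounds lacking any halogen on this group, with a 1.6-fold higher number from compound 2 to compound 4 (0.19 log units; within the scatter) and a 1.7-fold higher number from compound 1 to compound 4 (0.23 log units; within the scatter), both steps within the scatter. Among the groups shown at this position, compound 3 is therefore the only one with a number set apart from the rest, and its step from compound 2 and its step to compound 4 are both beyond the scatter.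

The step from compound 3 to compound 4 changes the thiocarbonyl and the halogen pattern together, so the shown compounds leave open which part accounts for the loss, a urea carrying the single iodo substituent being the direct test. Also open, as far as these compounds go, is whether a bromo or a methoxy group on the phenylthiourea would give a number like that of compound 3. Nothing available here offers an explanation for the gap between compound 3 and compound 4.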